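Shifting a trifluoromethyl around the amide aryl ring

This account rests on a few compounds, and the source may have more. Where it says the series, first, only, none or still open, it means among the compounds named here.

Measured compounds in an assay on isolated protein for inhibition of sodium- and chloride-dependent glycine transporter 1 (Homo sapiens); on this read-out higher numbers stand for weaker inhibition and lower numbers for stronger inhibition:
compound 1 `Cn1cnc(S(=O)(=O)N2C[C@@H]3[C@H](C2)[C@@]3(CNC(=O)c2cc(Cl)cc(Cl)c2)CC2CC2)c1` gives 100 nM
compound 2 `O=C(NC[C@]1(CC2CC2)[C@@H]2CN(S(=O)(=O)c3cccnc3)C[C@@H]21)c1ccc(Cl)cc1Cl` gives 890 nM
compound 3 `Cn1cnc(S(=O)(=O)N2C[C@@H]3[C@H](C2)[C@@]3(CNC(=O)c2ccccc2C(F)(F)F)CC2CC2)c1` gives 5 nM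

Compound 3 holds the lowest number of the three; compound 1 sits nearest, compound 2 furthest. Compound 4 `Cn1cnc(S(=O)(=O)N2C[C@@H]3[C@H](C2)[C@@]3(CNC(=O)c2cccc(C(F)(F)F)c2)CC2CC2)c1` differs from compound 3 by 3-(trifluoromethyl)phenyl in place of 2-(trifluoromethyl)phenyl on a carbonyl carbon. For the measured compounds named here, the one step that bears on the aryl group here is a 20-fold lower number from compound 1 to compound 3 (1.30 log units; beyond the scatter), where the 3,5-dichlorophenyl of compound 1 gave the weaker result. Going by the values given here, compound 2 offers no step with compound 3, since its sulfonyl group also differs. Because of the step of a 20-fold lower number from compound 1 to compound 3 (1.30 log units; beyond the scatter), the move to a 3-(trifluoromethyl)phenyl is expected to weaken inhibition, giving an estimated step of an 8.0-fold higher number from compound 3 to compound 4 (0.90 log units; beyond the scatter). Compound 4 is therefore estimated at 40 nM, within 10 nM to 200 nM.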

Compound 4, half-maximal inhibitory concentration: 64 nM
Compound 4: middle estimate off by 1.6-fold (0.20 log units), on the low side; the measured number falls inside the stated range.
By their numbers in this assay, from the lowest: compound 3; then compounds 4 and 1 (each within the scatter of the next); then compound 2.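

Moving the trifluoromethyl, with the same atoms joined differently, is itself a large change at this position: a 13-fold higher number from compound 3 to compound 4 (1.11 log units; beyond the scatter) in this assay. The gain seen with the 2-(trifluoromethyl)phenyl therefore depends on where the group sits on the aryl ring, not merely on its presence, while the 3-(trifluoromethyl)phenyl cannot be told apart from the 3,5-dichlorophenyl, with a 1.6-fold lower number from compound 1 to compound 4 (0.19 log units; within the scatter). No measurement here speaks to a cause for this difference. From the compounds shown here alone, whether a nitrile or a methoxy group in place of the trifluoromethyl of compound 3 would keep its inhibition remains open, as does whether this step holds with the sulfonyl group of compound 2.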